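From methyl to methoxy: a step not yet measured

The source may hold more compounds than are shown below. What is called first, only, known or untested is meant among the compounds shown, and "the series" means these compounds.

Measured compounds:
- compound 1 `Cc1ccc(CN(C)C(=O)c2cc(Cl)c(O)cc2O)cc1` gives 34300 nM here
- compound 2 `Cc1ccccc1CN(C)C(=O)c1cc(Cl)c(O)cc1O` gives 47500 nM here

Within the data shown here, in a functional assay on NCI-H1975 cells (Homo sapiens) for antiproliferative activity, with a stated time of 72 h (on this read-out lower numbers stand for stronger inhibition of growth and higher numbers for weaker inhibition of growth), compound 1 gives 34300 nM as one of only two numbers so far. Among the measured compounds shown here, the single measured step is a 1.4-fold higher number from compound 1 to compound 2 (0.14 log units; within the scatter) so the two values cannot be ranked.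

In compound 3 `COc1ccc(CN(C)C(=O)c2cc(Cl)c(O)cc2O)cc1` methoxy stands in place of methyl on an aromatic carbon, para to a large group, and the rest of compound 1 is kept. Counted, the change is methoxy in place of methyl on an aromatic carbon and nothing else differs.

For the measured compounds named here, no measured step makes this swap. Going by the values given here, the only step that bears on it, even indirectly, is a 1.4-fold higher number from compound 1 to compound 2 (0.14 log units; within the scatter) and that one merely moves the methyl group on its ring, so it says nothing direct about methoxy. On this thin evidence, no step beyond the scatter is expected in this assay and no direction can be favoured. The estimated step is a 1.0-fold higher number from compound 1 to compound 3 (0.01 log units; within the scatter) for now. Compound 3 is expected at about 35000 nM with an estimated range of 17000 nM to 70000 nM on this evidence.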

Compound 3, concentration for 50% growth inhibition: 16700 nM
Compound 3: middle estimate off by 2.1-fold (0.32 log units), on the high side; the measured number lies below the stated range.
By their numbers in this assay, from the lowest: compound 3; then compounds 1 and 2 (each within the scatter of the next).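

In this assay, among these compounds, methoxy in place of methyl gives a 2.1-fold lower number from compound 1 to compound 3 (0.31 log units; beyond the scatter), the first step in this small series to pass beyond the scatter. It shows that the number responds to what stands on this aromatic carbon, para to a large group, whereas moving the methyl group gave only a 1.4-fold higher number from compound 1 to compound 2 (0.14 log units; within the scatter), a shift too small to rank. The step is modest and rests on a single pair of compounds, so it shows that a change here can matter, but not how far the number can fall, and nothing shown here accounts for the drop.

From the compounds shown here alone, it remains open whether a longer chain such as ethoxy, or an amine, on this same carbon would lower the number further or raise it again. Also open, going by these compounds, is whether methoxy would give a similar step if it stood where compound 2 carries its methyl group, which would show whether the step belongs to methoxy in general or to methoxy at this one place on the ring.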